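Swapping Trifluoromethyl for Phenyl in a Glucagon Receptor Series

A few compounds are considered here, and "the series" means these few. Any claim that something is new, unique, unknown or untested is made for them only; others in the source may bear on it.

Compound 1 `CCCCCc1c(C(C)C)nc(C(C)C)c(CO)c1-c1ccc(C(F)(F)F)cc1` was tested in an assay on CHO cells for inhibition of Glucagon receptor (Homo sapiens), tested at 20 uM (on this read-out lower numbers stand for less inhibition and higher numbers for more inhibition at the one concentration tested (going by the name of the read-out)), where compound 1 gives 35%. For the measured compounds named here, this is the higher of the two numbers measured so far; the other measured member, compound 2 `CCC/C=C/c1c(C(C)C)nc(C(C)C)c(CO)c1-c1ccc(S(C)(=O)=O)cc1`, gives 14% in this assay, a gap that lies beyond the usual scatter. Compound 3 `CCCCCc1c(C(C)C)nc(C(C)C)c(CO)c1-c1ccc(-c2ccccc2)cc1` has not yet been measured. It differs from compound 1 in a single place (phenyl in place of trifluoromethyl on an aromatic carbon). Going by the values given here, no step between measured compounds bears on this change, so the expectation rests on compound 1 alone. Because compound 1 reaches 35%, compound 3 is expected to stay in the same region, with a step of a number 7 percentage points higher from compound 1 to compound 3 (within the scatter) that is expected to be small and upward and may not exceed the usual scatter. Compound 3 is therefore estimated at 42%, within a range from 12% to 75%.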

Compound 3, a percentage reported as inhibition, at one concentration (the size of the read-out at that concentration, not a potency): 2%
The estimate for compound 3 lay 40 percentage points above the measured number; the whole stated range lies above it.
By their numbers in this assay, from the lowest: compound 3; then compound 2; then compound 1.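

This position, on an aromatic carbon para to a large group, had not been touched by any earlier step, and it now proves able to move the read-out with the rest of compound 1 held fixed. In this assay, phenyl in place of trifluoromethyl gives a number 33 percentage points lower from compound 1 to compound 3 (beyond the scatter), so a single exchange here is enough to take away most of the inhibition seen at the one concentration tested. Nothing measured alongside this result explains the size of the step.

The compounds shown leave open whether the drop belongs to phenyl in particular or would also follow from other groups at this position, such as methyl, chlorine or a pyridine ring. They also leave open how a phenyl ring carrying an amine or a carboxylic acid would read here.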